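The source may report more compounds than this note shows. Statements on the series, on what has been measured and on what is new or still open speak of the compounds shown alone.

Measured so far in the series:

- compound 1 `CN(C)c1ncnc2c1ncn2Cc1ccc(N)cc1`; in a functional assay on the whole organism with Rattus norvegicus as the target, in the maximal electroshock model (a higher number here means that more compound is needed for the effect, a lower number that less compound is needed), compound 1 gives 25 mg/kg
- compound 2 `CN(C)c1ncnc2c1ncn2Cc1cccc(C(F)(F)F)c1`; in this assay compound 2 gives 12 mg/kg

Compound 2 stands at the lower of the two numbers; compound 1 needs the higher dose, and the gap between the two is beyond the scatter. The two compounds differ in more than one place, so the gap cannot be tied to a single change.

Compound 3 `CN(C)c1ncnc2c1ncn2Cc1cccc(F)c1` is the next compound, not yet measured in this assay. Against compound 2 the change is fluoro in place of trifluoromethyl on an aromatic carbon, with the rest of the molecule held as it is.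

Within the data shown here, no measured pair shows this kind of exchange, so the size of the step is open. The expectation is a small step at most, if anything toward a higher number, and likely within the scatter of this assay. For compound 3 in this assay the estimate is 18 mg/kg, with a range of 8 mg/kg to 40 mg/kg. The expected step of a 1.5-fold higher number from compound 2 to compound 3 (0.18 log units; within the scatter) reflects that uncertainty.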

Compound 3, dose for half-maximal effect: 8.4 mg/kg
For compound 3 the middle estimate is 2.1-fold (0.33 log units) above the measured one, within the range that was stated.
By their numbers in this assay, from the lowest: compounds 3 and 2 (each within the scatter of the next); then compound 1.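

Fluoro in place of trifluoromethyl on an aromatic carbon gives a 1.4-fold lower number from compound 2 to compound 3 (0.15 log units; within the scatter) in this assay and so leaves compound 2 and compound 3 indistinguishable. Among these compounds, this is the first single-place comparison, and at this position, meta to a large group, the two groups are not separated by dose, despite the difference in heavy atoms between them. No measurement of any property of these groups bears on this result.

From the compounds shown here alone, only these two halogen-bearing groups have been compared at this position, neither with a hydrogen-bond donor or acceptor or a net charge, so the reach of this result remains unknown. Going by these compounds, whether a nitrile, a carboxylic acid or a longer alkyl chain at the same place would keep the dose in this range stays open.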